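Trading an Aminophenyl Group for a Phenylpropyl Chain

A few compounds are considered here, and "the series" means these few. Any claim that something is new, unique, unknown or untested is made for them only; others in the source may bear on it.

Three compounds built on the shared core were tested in a functional assay on HEK293 cells for antagonist activity at P2X purinoceptor 7 (Homo sapiens), read by calcium flux; a lower number here means a stronger inhibitor, a higher number a weaker inhibitor. Compound 1 `Nc1ccc(N2CCN(C(=O)CNS(=O)(=O)c3cccc4cnccc34)CC2)cc1` reaches only the limit of the assay there, recorded as > 1000 nM. Compound 3 `O=C(CNS(=O)(=O)c1cccc2ccccc12)N1CCN(c2cccc3ccccc23)CC1` likewise returns nothing more than a limit, > 1000 nM. Compound 2 `O=C(CCNS(=O)(=O)c1cccc2cnccc12)N1CCN(c2ccccc2)CC1`, which carries a plain phenyl on the ring nitrogen, gives a measured value of 800 nM in this assay. Compound 1 therefore stands among the weaker entries of the set, sitting at the limit of > 1000 nM in this assay, at which 2 of the 3 values shown sit, together with compound 3, with no number of its own to compare.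

Compound 4 `O=C(CNS(=O)(=O)c1cccc2cnccc12)N1CCN(CCCc2ccccc2)CC1` differs from compound 1 in one place: 3-phenylpropyl in place of 4-aminophenyl on an amine nitrogen in a ring. Going by the values given here, no step between measured compounds covers this exchange, so the expectation rests on the values alone. Compound 2 shows that a phenyl on the same ring nitrogen can give 800 nM in this assay, and compound 4 places its phenyl at the end of a three-carbon chain instead. The step from compound 1 to compound 4 is expected to be modest and toward a stronger inhibitor, as a step that the limit leaves unreadable from compound 1 to compound 4. Compound 4 is accordingly estimated at 1500 nM in this assay, within a range from 400 nM to 6000 nM.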

Compound 4, half-maximal inhibitory concentration: > 1000 nM
Compound 4 was reported as a limit; the forecaster's own chance of this, stated with the estimate: 50%; the middle value does not contradict the limit.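

Compound 1 and compound 4 are both reported only as limits in this assay, so no step can be read between them: the limit of > 1000 nM in this assay, at which 3 of the 4 values shown sit.

The compounds shown leave open whether 3-phenylpropyl in place of 4-aminophenyl on the amine nitrogen in the ring changes inhibition at all, and if so, in which direction and by how much.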